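A few compounds are considered here, and "the series" means these few. Any claim that something is new, unique, unknown or untested is made for them only; others in the source may bear on it.

Compound 1 `CS(=O)(=O)c1ccc(C(=O)N2CCC(C(=O)N3CCc4ccccc4C3)CC2)cc1[N+](=O)[O-]`: in an ADME assay on HepG2 cells (Homo sapiens) for cytotoxicity, read by CellTiter-Glo and ATP content, with a stated time of 72 h (on this read-out higher numbers stand for an effect only at larger amounts of compound and lower numbers for an effect already at smaller amounts), compound 1 gives > 27000 nM, a limit of the assay.
Compound 2 `CN1CCN(C(=O)C2CCN(C(=O)c3ccc(S(C)(=O)=O)c([N+](=O)[O-])c3)CC2)CC1`: compound 2 gives > 27000 nM, a limit.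
Compound 3 `CN(Cc1ccccc1F)C(=O)C1CCN(C(=O)c2ccc(S(C)(=O)=O)c([N+](=O)[O-])c2)CC1`: compound 3 gives > 27000 nM, a limit.

Compound 3 stands where every measured compound stands, at the limit of > 27000 nM in this assay, at which 3 of the 3 values shown sit. The next compound is compound 4 `CC1Cc2ccccc2N1C(=O)C1CCN(C(=O)c2ccc(S(C)(=O)=O)c([N+](=O)[O-])c2)CC1`; the change is 2-methyl-2,3-dihydro-1H-indol-1-yl in place of (2-fluorobenzyl)(methyl)amino on a carbonyl carbon. Two measured steps end at compound 3, a step that the two limits leave unreadable from compound 1 to compound 3 and a step that the two limits leave unreadable from compound 2 to compound 3, and a third, a step that the two limits leave unreadable from compound 1 to compound 2, connects the other two compounds; each has a limit at both ends, so no size can be read from any of them. The expected step that the limit leaves unreadable from compound 3 to compound 4 is therefore set at none beyond the scatter. Compound 4 is expected to give 40000 nM, with a range from 15000 nM to 100000 nM, most likely reported once more only as a limit.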

Compound 4, half-maximal effective concentration: > 27000 nM
Compound 4: only a limit was reported (the forecaster's own chance of this, stated with the estimate: 85%); the middle value is on the limit's open side.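

Compound 4, like compound 1, compound 2 and compound 3, is reported only as a limit in this assay, and none of the steps to compound 4 can be read. The compounds shown leave open whether the groups exchanged on the carbonyl carbon differ at all in this assay.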